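A few compounds are considered here, and "the series" means these few. Any claim that something is new, unique, unknown or untested is made for them only; others in the source may bear on it.

Measured to date in an assay for inhibition of MAP kinase-interacting serine/threonine-protein kinase 2 (Homo sapiens), read by luminescence and ADP-Glo, with a stated time of 2 h; a higher number here means a weaker inhibitor, a lower number a stronger inhibitor:
Compound 1, `O=c1ccc(-c2ccc3cn[nH]c3c2)cn1Cc1ccccc1`, gives 75 nM.
Compound 2, `O=c1ccc(-c2ccc3cn[nH]c3c2)cn1Cc1cccc(F)c1`, gives 38 nM.
Compound 3, `O=c1ccc(-c2ccc3cn[nH]c3c2)cn1Cc1ccccc1F`, gives 37 nM.

Compound 3 holds the lowest number of the three. Its gap to compound 2 lies within the scatter, so no order between those two can be read; the step of a 2.0-fold lower number from compound 1 to compound 3 (0.31 log units; beyond the scatter) is a modest one but beyond the scatter. The parallel step a 2.0-fold lower number from compound 1 to compound 2 (0.30 log units; within the scatter) lands within the scatter, and the step of a 1.0-fold lower number from compound 2 to compound 3 (0.01 log units; within the scatter) shows the two fluoro placements giving the same result.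

Compound 4, `Cn1cc(-c2ccc3cn[nH]c3c2)ccc1=O`, differs from compound 3 by hydrogen in place of 2-fluorophenyl on a saturated chain carbon bound to an aromatic nitrogen. Within the data shown here, no measured step resembles this one: the measured steps exchange fluoro for hydrogen on the six-membered aromatic ring of carbon only, or move the fluoro on it, while that ring itself is present in every measured compound. Those steps were small; removal of the whole group is a larger change, and its direction cannot be read from the measured pairs. The expected step of a 14-fold higher number from compound 3 to compound 4 (1.13 log units; beyond the scatter) is therefore set wide, leaning toward a higher number. Compound 4 is estimated at 500 nM, range 120 nM to 2500 nM.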

Compound 4, half-maximal inhibitory concentration: > 2000 nM
Compound 4 ended at the assay's limit; the forecaster's own chance of this, stated with the estimate: 5%; middle value at least 4.0-fold (0.60 log units) away from the limit.
By their numbers in this assay, from the lowest: compounds 3, 2 and 1 (each within the scatter of the next, the first and the last beyond it). At a limit, above all of these: compound 4.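

In this assay compound 4 gives > 2000 nM which is a limit of the assay and not a number: the limit of > 2000 nM in this assay, at which 1 of the 4 values shown sits.

Hydrogen in place of the whole aryl group on a saturated chain carbon bound to an aromatic nitrogen, which reads as methyl in place of benzyl when cut one bond further out, is a large step from each of the three earlier compounds (an at least 54-fold higher number from compound 3 to compound 4 (1.73 log units; beyond the scatter)) (an at least 52-fold higher number from compound 2 to compound 4 (1.72 log units; beyond the scatter)) (an at least 26-fold higher number from compound 1 to compound 4 (1.42 log units; beyond the scatter)). The earlier compounds shown here changed only fluoro on a ring that every one of them kept, and those steps stayed small, so they could not show how much depends on the ring being there at all. Across these four compounds, the presence of the six-membered aromatic ring at this position counts for far more than the fluoro on it.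

The compounds shown leave open what between methyl and benzyl would restore inhibition, and whether the ring must be aromatic or whether a longer chain such as propyl, a cyclohexylmethyl group or a pyridylmethyl group would serve. The limit also leaves the true size of the loss unknown.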